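Alkylphenyl urea series: butyl chain extended by a methyl

The compounds below may be only part of what the source reports. "The series", "measured", "known", "first", "only" and "open" are said of these compounds alone.

Measured in an ADME assay on the whole organism with Oryza sativa as the target, tested at 1 uM; a lower number here means a stronger effect, a higher number a weaker effect of the compound at the concentration tested:
compound 1 `CC(C)c1ccc(NC(=O)N[C@@H](C)c2ccccc2)cc1`: 96%
compound 2 `C[C@H](NC(=O)Nc1ccc(C(C)(C)C)cc1)c1ccccc1`: 88%
compound 3 `CCCCc1ccc(NC(=O)N[C@@H](C)c2ccccc2)cc1`: 72%

Compound 3 stands lowest of the three in this assay; its gaps to compound 2 and to compound 1 are both beyond the scatter. Compound 4 `CCCCCc1ccc(NC(=O)N[C@@H](C)c2ccccc2)cc1` differs from compound 3 by methyl in place of hydrogen on a saturated chain carbon, four bonds along the chain from an aromatic carbon. Going by the values given here, no measured step lengthens a straight chain. The two steps beyond the scatter, a number 24 percentage points lower from compound 1 to compound 3 (beyond the scatter) and a number 16 percentage points lower from compound 2 to compound 3 (beyond the scatter), exchange a branched group for straight butyl, and a number 8 percentage points lower from compound 1 to compound 2 (within the scatter) adds a methyl on a branched chain. They do not settle the direction of a further methyl on the straight chain, so only a small step, near the scatter and if anything downward, is expected: a number 8 percentage points lower from compound 3 to compound 4 (within the scatter). Compound 4 is therefore estimated at 64%, expected between 46% and 82%.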

Compound 4, a percentage reported as activity, at one concentration (the size of the read-out at that concentration, not a potency): 98%
Compound 4: the middle estimate sits 34 percentage points below what was measured, and the stated range ends below it.
By their numbers in this assay, from the lowest: compound 3; then compounds 2, 1 and 4 (each within the scatter of the next).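

In this assay, the position four bonds along the chain from an aromatic carbon proves sensitive, and adding a methyl there removes the low reading seen with butyl: a number 26 percentage points higher from compound 3 to compound 4 (beyond the scatter). Pentyl does not stand apart from the branched groups: a number 10 percentage points higher from compound 2 to compound 4 (within the scatter), and a number 2 percentage points higher from compound 1 to compound 4 (within the scatter). Methyl in place of hydrogen therefore does not carry over as a constant step between these chains: the same change on two cores in this assay, a number 8 percentage points lower (within the scatter) from compound 1 to compound 2 and a number 26 percentage points higher (beyond the scatter) from compound 3 to compound 4, 34 percentage points apart, beyond the scatter of two such steps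

On these data alone, whether butyl marks a narrow low point remains open, since a propyl or hexyl chain would be needed to define the trend. As far as these compounds go, how a chain carrying a hydroxyl would read in this assay is also open.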